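Benzothiazolyl triazole analogue: expected cytotoxicity in the series

A few compounds are considered here, and "the series" means these few. Any claim that something is new, unique, unknown or untested is made for them only; others in the source may bear on it.

Working notes. The compounds share one core and differ only in the group on the aromatic nitrogen of the triazole. Compound 1 `COc1ccc(/C=C\C(=O)O)c(OCc2cn(-c3cccc(C#N)c3)nn2)c1CC=C(C)C` gives in a functional assay on COLO 205 cells (Homo sapiens) for cytotoxicity, read by MTT assay, with a stated time of 24 h (a higher number here means a weaker inhibitor, a lower number a stronger inhibitor), a value of 26800 nM. Compound 2 `COc1ccc(/C=C\C(=O)O)c(OCc2cn(-c3ccccc3)nn2)c1CC=C(C)C` gives in this assay a value of 32300 nM. Among the measured compounds shown here, the single step measured, a 1.2-fold higher number from compound 1 to compound 2 (0.08 log units; within the scatter), shows that swapping the substituent on that phenyl leaves the number essentially unchanged. Going by these compounds, compound 3 `COc1ccc(-n2cc(COc3c(/C=C\C(=O)O)ccc(OC)c3CC=C(C)C)nn2)cc1` carries a 4-methoxyphenyl on the same nitrogen; in this assay compound 3 gives "not determined" (no result reported), so its standing relative to compound 1 and compound 2 is unknown. Compound 4 `COc1ccc(/C=C\C(=O)O)c(OCc2cn(-c3nc4ccccc4s3)nn2)c1CC=C(C)C` differs from compound 3 by 1,3-benzothiazol-2-yl in place of 4-methoxyphenyl on an aromatic nitrogen. For the measured compounds named here, the only step that bears on a change at this position is the one from compound 1 to compound 2, and that step lay within the scatter; no measured step covers a heteroaromatic group here, so the expectation rests on the two measured compounds alone. Compound 4 is therefore expected to give in this assay a value of about 25000 nM, with a range of 8000 nM to 80000 nM.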

Compound 4, half-maximal inhibitory concentration: 20200 nM
Compound 4: middle estimate off by 1.2-fold (0.09 log units), on the high side; low and high end bracket the measured number.
By their numbers in this assay, from the lowest: compounds 4, 1 and 2 (each within the scatter of the next).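

Compound 4 extends this position from aromatic rings of carbon only to a group that also holds a five-membered aromatic ring with 2 hetero atoms, and in this assay the two readable steps are (a 1.6-fold lower number from compound 2 to compound 4 (0.20 log units; within the scatter)) and (a 1.3-fold lower number from compound 1 to compound 4 (0.12 log units; within the scatter)). Replacing either phenyl group with 1,3-benzothiazol-2-yl therefore leaves the number within the scatter, so none of the three compounds with a value shows a step at this nitrogen that exceeds it. No evidence is available that would explain this flat result.

Steps involving compound 3 cannot be read, so the standing of 4-methoxyphenyl remains unknown. Going by these compounds, it also remains open whether an amine or a longer chain on this aromatic nitrogen would move the number beyond the scatter.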